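Demethylation of compound 2: expected effect on cytotoxicity

The source may hold more compounds than are shown below. What is called first, only, known or untested is meant among the compounds shown, and "the series" means these compounds.

The series is tested in a functional assay on B16-BL6 cells (Mus musculus) for cytotoxicity, read by MTT assay, with a stated time of 72 h; on this read-out higher numbers stand for weaker inhibition and lower numbers for stronger inhibition. Compound 1 `COc1cc(O)cc2c1OC[C@H](Cc1ccc(O)cc1)C2` reaches only the limit of the assay, > 100000 nM. Compound 3 `Oc1ccc(C[C@H]2COc3cc(O)ccc3C2)cc1` likewise gives only a limit, > 100000 nM. Among the compounds with values here, compound 2 `COc1ccc(CCC(=O)c2ccc(O)cc2)c(OC)c1` is the one compound with a measured number, 55500 nM. Set against (the limit of > 100000 nM in this assay, at which 2 of the 3 values shown sit), compound 2 stands alone as the sole numeric result. Compound 4 `COc1ccc(CCC(=O)c2ccc(O)cc2)c(O)c1` is not yet measured. It differs from compound 2 by hydrogen in place of methyl on an oxygen on an aromatic ring. Within the data shown here, no step between measured compounds is available to size this change, so no shift beyond the scatter is expected in either direction. The step of a 1.1-fold lower number from compound 2 to compound 4 (0.05 log units; within the scatter) is therefore expected to stay within the scatter. Compound 4 is expected to give about 50000 nM, in the range 15000 nM to 150000 nM.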

Compound 4, half-maximal inhibitory concentration: 57800 nM
Compound 4: middle estimate off by 1.2-fold (0.06 log units), on the low side, and the stated range covers the measured number.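

In this assay the series now has its first sized step, a 1.0-fold higher number from compound 2 to compound 4 (0.02 log units; within the scatter), for hydrogen in place of methyl on an oxygen on an aromatic ring. At this place, methoxy to hydroxy leaves the read-out unchanged, so this methyl is not required for the cytotoxicity seen with compound 2. Nothing in the data given accounts for this result.

Still open, as far as these compounds go, is whether a longer chain on this oxygen, or an amine in its place, would move the number. Within the data shown here, the methoxy retained in compound 4 also has no step of its own.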